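The source may report more compounds than this note shows. Statements on the series, on what has been measured and on what is new or still open speak of the compounds shown alone.

Compound 3, with the structure `CC(C)CC1(O)CCN(C(=O)Nc2cc(Oc3ccc(C(=O)O)cc3)cc(Oc3ccc(F)c(F)c3)c2)CC1`, was tested in an ADME assay on the whole organism for pharmacokinetics, with Rattus norvegicus as the target, with a stated time of 24 h, at a dose of 1 mg/kg by the oral route (a lower number here means less compound in the circulation, a higher number more compound in the circulation at the dose given), and gives 62 ng.h/mL. Within the data shown here, of the three numbers known so far that is the lowest: compound 1, `CC(C)CC1(O)CCN(C(=O)Nc2cc(Oc3ccc(C(=O)O)cc3)cc(Oc3ccc(F)cc3F)c2)CC1`, gives 65 ng.h/mL, and the step of a 1.0-fold lower number from compound 1 to compound 3 (0.02 log units; within the scatter) is within the scatter, so the two cannot be told apart. Among the measured compounds shown here, compound 2, `CC(C)CC1(O)CCN(C(=O)Nc2cc(Oc3ccc(F)cc3)cc(Oc3ccc(CC(=O)O)cc3)c2)CC1`, gives 787 ng.h/mL, a higher number, but it differs from compound 3 in more than one place and no single step connects them.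

Compound 4 is `CC(C)CC1(O)CCN(C(=O)Nc2cc(Oc3ccc(F)cc3)cc(Oc3ccc(C(=O)O)cc3)c2)CC1`. Relative to compound 3 the change is hydrogen in place of fluoro on an aromatic carbon: one fluorine leaves, a hydrogen enters, ortho to a fluoro group and meta to a large group, so that 3,4-difluorophenoxy becomes 4-fluorophenoxy.

For the measured compounds named here, the only measured step that bears on this edge of the molecule is the move of a fluorine from 2,4-difluorophenyl to 3,4-difluorophenyl, a 1.0-fold lower number from compound 1 to compound 3 (0.02 log units; within the scatter), which stayed within the scatter. Removing a fluorine from the same ring is a smaller change of the same kind, and nothing known points in either direction. He therefore expects no step beyond the scatter, a 1.1-fold higher number from compound 3 to compound 4 (0.05 log units; within the scatter), and estimates that compound 4 will give 70 ng.h/mL in this assay, within a range of 30 ng.h/mL to 160 ng.h/mL.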

Compound 4, area under the concentration-time curve: 70 ng.h/mL
For compound 4 middle estimate and measured number coincide at the digits printed, and the stated range covers the measured number.
By their numbers in this assay, from the lowest: compounds 3, 1 and 4 (each within the scatter of the next); then compound 2.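

In this assay, taking one fluoro away from the 3,4-difluorophenoxy ring to leave 4-fluorophenoxy gives a step that stays inside the scatter (a 1.1-fold higher number from compound 3 to compound 4 (0.05 log units; within the scatter)), and the same holds when the comparison starts from the 2,4-difluorophenyl compound (a 1.1-fold higher number from compound 1 to compound 4 (0.03 log units; within the scatter)), so a second fluoro on this ring, in either of the two places shown, makes no difference that can be read here. Compound 4 also gives compound 2 its first single-place neighbour, and carboxy in place of carboxymethyl on an aromatic carbon is a large step (an 11-fold lower number from compound 2 to compound 4 (1.05 log units; beyond the scatter)), so among these compounds the change on the acid-bearing ring, and not the fluoro pattern on the other ring, is the one that moves the number. Nothing measured here explains either result.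

Going by these compounds, whether a phenoxy ring with no fluoro at all, or with chloro or methoxy in the place of the fluoro, would stay with compound 4 remains open. So does the effect of a longer chain such as carboxyethyl on the other ring, and whether the large step from carboxymethyl to carboxy would also appear with a difluorophenoxy ring.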